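Swapping the isobutoxy group of compound 2 for hydroxy

A few compounds are considered here, and "the series" means these few. Any claim that something is new, unique, unknown or untested is made for them only; others in the source may bear on it.

Compound 4 `O=c1c(Cc2coc3cccc(O)c3c2=O)coc2ccccc12` has not yet been tested in a functional assay on HCT-15 cells (Homo sapiens) for antiproliferative activity, read by XTT assay (a higher number here means a weaker inhibitor, a lower number a stronger inhibitor), but three relatives have. Compound 1 `O=c1c(Cc2coc3cccc(OCC4CCCCC4)c3c2=O)coc2cc(Cl)ccc12` gives > 10000 nM, which is a limit and not a number. Compound 2 `CC(C)COc1cccc2occ(Cc3coc4ccccc4c3=O)c(=O)c12` gives > 10000 nM, also a limit. Compound 3 `Cc1ccc2c(=O)c(Cc3coc4cccc(OCC5CCCCC5)c4c3=O)coc2c1` gives a true number, 2220 nM. Most of this small set therefore sits at the limit of > 10000 nM in this assay, at which 2 of the 3 values shown sit.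

Compound 4 differs from compound 2 by one change, hydrogen in place of isobutyl on an oxygen on an aromatic ring. Within the data shown here, no tested compound carries this hydroxy group. Among the measured compounds shown here, the only measured step is an at least 4.5-fold lower number from compound 1 to compound 3 (0.65 log units; beyond the scatter), with methyl in place of chloro on an aromatic carbon. That is a different change, so it offers only a rough guide: one swap can shift the number in this series. On these data alone, the starting point is only a limit, so the direction stays open, and a small step is expected: a number no higher from compound 2 to compound 4 (the limit leaves the size open). Compound 4 is estimated at 10000 nM, with an expected range from 3000 nM to 30000 nM.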

Compound 4, half-maximal inhibitory concentration: > 10000 nM
Compound 4 ended at the assay's limit; the forecaster's own chance of this, stated with the estimate: 65%; the middle value lies on the limit itself.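

Among these compounds, compound 2 and compound 4 each give only a limit of the assay and not a number, so no step between them can be read in this assay. The compounds shown leave open whether hydroxy in place of isobutoxy shifts the number at all, and most values here share one limit: the limit of > 10000 nM in this assay, at which 3 of the 4 values shown sit.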